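Fluorine on a Phenyl Ring in Two Kinase Cores

A few compounds are considered here, and "the series" means these few. Any claim that something is new, unique, unknown or untested is made for them only; others in the source may bear on it.

Measured so far:
compound 1, `Clc1ncnc2ncn(Cc3ccccc3)c12`, gives 0% in an assay on isolated protein for inhibition of RAC-alpha serine/threonine-protein kinase (Homo sapiens), tested at 30 uM; a lower number here means less inhibition, a higher number more inhibition at the concentration tested (going by the name of the read-out);
compound 2, `Fc1ccc(Cn2cnc3ncnc(Cl)c32)cc1`, gives 0%;
compound 3, `Cn1c(-c2ccc(S(C)(=O)=O)cc2)nc2c(Sc3ccccc3)ncnc21`, gives 14%.

Compound 2 is compound 1 with fluoro in place of hydrogen on an aromatic carbon, and that step made no change at the digits printed from compound 1 to compound 2 (within the scatter). Compound 3 carries a different core; the difference between the two cores is not broken down here. Compound 3 also stands highest of the three measured values. Compound 4, `Cn1c(-c2ccc(S(C)(=O)=O)cc2)nc2c(Sc3ccc(F)cc3)ncnc21`, is compound 3 with the same change, (fluoro in place of hydrogen on an aromatic carbon). Among the compounds with values here, the one earlier example of this change left the read-out where it was, so the step from compound 3 to compound 4 is expected to be small, no change at the digits printed from compound 3 to compound 4 (within the scatter). Compound 4 is therefore estimated to give 14%, most likely between 2% and 28%.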

Compound 4, a percentage reported as inhibition, at one concentration (the size of the read-out at that concentration, not a potency): 4%
Compound 4: the middle estimate sits 10 percentage points above what was measured; the range from low to high includes it.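

On the core with the methylsulfonylphenyl group, going from phenylsulfanyl to (4-fluorophenyl)sulfanyl gives a number 10 percentage points lower from compound 3 to compound 4 (within the scatter). Set beside the earlier example, the change reads the same on both cores in this assay: the same change on two cores in this assay, no change at the digits printed (within the scatter) from compound 1 to compound 2 and a number 10 percentage points lower (within the scatter) from compound 3 to compound 4, 10 percentage points apart, within the scatter of two such steps. Within the data shown here, this shows only that neither step can be told apart from repeat-measurement noise; with so few examples, all from a single test concentration and all with low read-outs, it does not show that the change would carry over to other cores or leave true potency untouched.

As far as these compounds go, it remains open whether a different group in place of that same hydrogen, such as an amine or a carboxylic acid, would shift the read-out beyond the scatter on either core.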